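Swapping the aryl group in a vinyl sulfide chalcone-like series

This account rests on a few compounds, and the source may have more. Where it says the series, first, only, none or still open, it means among the compounds named here.

Measured compounds:
compound 1 `Cc1ccc(CS/C(=C/c2cc(C)ccc2C)C(=O)c2ccc(Cl)cc2)cc1` gives 10000 nM in a functional assay on DU-145 cells (Homo sapiens) for inhibition, read by trypan blue exclusion, with a stated time of 96 h; a higher number here means a weaker inhibitor of growth, a lower number a stronger inhibitor of growth
compound 2 `Cc1ccc(C)c(/C=C(/SCc2ccc(Cl)cc2)C(=O)c2ccc(Cl)cc2)c1` gives 10000 nM

Among the measured compounds shown here, compound 1 stands level with compound 2; the one recorded step, no change at the digits printed from compound 1 to compound 2 (within the scatter), changes the benzylic aryl only. Compound 3 `Cc1ccc(CS/C(=C/c2ccccc2Br)C(=O)c2ccc(Cl)cc2)cc1` alters a different part: 2-bromophenyl in place of 2,5-dimethylphenyl on a double-bonded chain carbon bound to a double-bonded chain carbon. For the measured compounds named here, no measured step touches this position, so nothing recorded bears on it directly, and the only information is that the series sits at a weak level in this assay. An unchanged result is therefore expected, no change at the digits printed from compound 1 to compound 3 (within the scatter). Compound 3 is estimated at 10000 nM, within 3000 nM to 30000 nM.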

Compound 3, concentration for 50% growth inhibition: 10000 nM
Compound 3: the middle estimate sits on the measured number at the digits printed, within the range that was stated.
By their numbers in this assay, from the lowest: compounds 1, 2 and 3 (each within the scatter of the next).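

In this assay, 2-bromophenyl in place of 2,5-dimethylphenyl on a double-bonded chain carbon bound to a double-bonded chain carbon gives no change at the digits printed from compound 1 to compound 3 (within the scatter). Among the compounds shown here, this is the first recorded change at this position, and it shows that this exchange of aryl groups leaves the read-out where it was. Nothing available explains this outcome.

On these data alone, whether any group at this place can move the series from its weak level stays open. An amine or a carboxylic acid on this aryl group would test that.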